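The source may hold more compounds than are shown below. What is called first, only, known or untested is meant among the compounds shown, and "the series" means these compounds.

In a functional assay on DU-145 cells (Homo sapiens) for inhibition, read by trypan blue exclusion, with a stated time of 72 h (a higher number here means a weaker inhibitor, a lower number a stronger inhibitor), compound 1 `COc1ccc(S(=O)(=O)c2cc3cnc(Nc4ccc5[nH]ccc5c4)nc3n(C)c2=O)cc1` gives 500 nM. Compound 2 `Cn1c(=O)c(C(=O)Nc2ccc(F)cc2)cc2cnc(Nc3ccc4[nH]ccc4c3)nc21`, with (4-fluorophenyl)carbamoyl in place of (4-methoxyphenyl)sulfonyl, gives 5000 nM. Compound 3 `COc1ccc(S(=O)(=O)c2cc3cnc(Nc4cccc5[nH]ccc45)nc3n(C)c2=O)cc1`, with 1H-indol-4-yl in place of 1H-indol-5-yl, gives 5000 nM. Compound 3 therefore stands level with compound 2, and both are weaker inhibitors than compound 1.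

Compound 4 `Cc1ccc(S(=O)(=O)c2cc3cnc(Nc4cccc5[nH]ccc45)nc3n(C)c2=O)cc1` keeps all of compound 3 except one small group: methyl in place of methoxy on an aromatic carbon, para to a large group, which turns (4-methoxyphenyl)sulfonyl into (4-methylphenyl)sulfonyl (methyl in place of methoxy on an aromatic carbon). Going by the values given here, no measured pair makes this exact swap, so the data offer no direct test.

The nearest guide is the replacement of the whole (4-methoxyphenyl)sulfonyl, which gave a 10-fold higher number from compound 1 to compound 2 (1.00 log units; beyond the scatter), a modest step beyond the scatter. The indole change gave a 10-fold higher number from compound 1 to compound 3 (1.00 log units; beyond the scatter), but it lies in another part of the molecule and serves only as a general measure of step size. The present change touches only the end of that same group, so a smaller step is expected, probably none beyond the scatter and with no favoured direction, in this assay. The expected step is no change at the digits printed from compound 3 to compound 4 (within the scatter). For compound 4 the estimated value is 5000 nM, within an expected range of 2000 nM to 12000 nM.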

Compound 4, half-maximal inhibitory concentration: 10000 nM
Beside the measured number, compound 4's estimate is 2.0-fold (0.30 log units) below it, within the range that was stated.
By their numbers in this assay, from the lowest: compound 1; then compounds 2, 3 and 4 (each within the scatter of the next).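

In this assay, going by these compounds alone, the exchange of methoxy for methyl on the 4-substituted phenyl of the sulfonyl group gives a 2.0-fold higher number from compound 3 to compound 4 (0.30 log units; within the scatter), so this is the first reading of a change confined to the end of that group rather than a replacement of the whole group. Within this pair, the oxygen and the one hydrogen-bond acceptor counted with methoxy can leave without a step beyond the scatter, and the two numbers should be read as the same level rather than as a loss. No measurement given here explains this result, and the pair alone cannot show what methoxy or methyl contributes at this place.

On these data alone, this reading comes only from compounds carrying 1H-indol-4-yl, so it remains open whether the same exchange would also stay within the scatter on compound 1, which carries 1H-indol-5-yl and gives 500 nM. The compounds shown also leave open how this place would respond to a group of a different kind, such as an amine, a carboxylic acid or a longer chain.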